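From compound 3 to compound 4: a new nitrogen substituent

The source may report more compounds than this note shows. Statements on the series, on what has been measured and on what is new or still open speak of the compounds shown alone.

Compound 1 `Nc1ncnc2c1c(-c1cc3ccccc3o1)cn2[C@H]1CCN(C[C@@H]2CO2)C1` gives 2820 nM
Compound 2 `Nc1ncnc2c1c(-c1cc3ccccc3o1)cn2[C@H]1CCN(C[C@H]2CO2)C1` gives 630 nM
Compound 3 `Nc1ncnc2c1c(-c1ccc(Oc3ccccc3)cc1)cn2C[C@H]1CCCN1C(CO)CO` gives 14500 nM

In a functional assay on JeKo-1 cells (Homo sapiens) for antiproliferative activity (a higher number here means a weaker inhibitor, a lower number a stronger inhibitor), compound 3, at 14500 nM, has the highest number of the three. Compound 4 `Nc1ncnc2c1c(-c1ccc(Oc3ccccc3)cc1)cn2C[C@H]1CCCN1C[C@@H]1CO1` carries (oxiran-2-yl)methyl in place of 2-hydroxy-1-(hydroxymethyl)ethyl on an amine nitrogen in a ring. Going by the values given here, no measured step makes this exact swap. The nearest evidence is that compound 1, at 2820 nM, and compound 2, at 630 nM, both carry (oxiran-2-yl)methyl on a different remainder and both sit lower. Their modest gap, a 4.5-fold lower number from compound 1 to compound 2 (0.65 log units; beyond the scatter), comes down to the fact that compounds 1 and 2 differ only in the configuration as drawn, which widens the uncertainty. A clear fall is therefore expected in this assay, an estimated 8.1-fold lower number from compound 3 to compound 4 (0.91 log units; beyond the scatter) overall. The expected value for compound 4 is 1800 nM (350 nM to 9000 nM).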

Compound 4, half-maximal inhibitory concentration: 11100 nM
Compound 4: middle estimate off by 6.2-fold (0.79 log units), on the low side, and the stated range ends below it.
By their numbers in this assay, from the lowest: compound 2; then compound 1; then compounds 4 and 3 (each within the scatter of the next).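

In this assay, placing (oxiran-2-yl)methyl on the amine nitrogen in place of 2-hydroxy-1-(hydroxymethyl)ethyl gives a 1.3-fold lower number from compound 3 to compound 4 (0.12 log units; within the scatter), so on this remainder the two groups cannot be told apart. The lower numbers of compounds 1 and 2 therefore cannot be credited to (oxiran-2-yl)methyl alone, since the rest of those molecules differs as well. Nothing shown accounts for this flat result.

As far as these compounds go, it remains open whether the opposite oxirane configuration would matter on this remainder. Equally open, from the compounds shown here alone, is how a methyl group, a longer chain or a carboxylic acid would fare on this nitrogen.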